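This account rests on a few compounds, and the source may have more. Where it says the series, first, only, none or still open, it means among the compounds named here.

The series shares one core: compound 1 `CNc1ncnc2c1c(-c1ccccc1)cn2[C@@H]1O[C@H](CO)[C@@H](O)[C@H]1O`, compound 2 `Nc1nc(N)c2c(-c3ccccc3)cn([C@@H]3O[C@H](CO)[C@@H](O)[C@H]3O)c2n1` and compound 3 `Cc1nc(N)c2c(-c3ccccc3)cn([C@@H]3O[C@H](CO)[C@@H](O)[C@H]3O)c2n1` differ only in substituents on that core. In a functional assay on CEM-DNR-bulk cells (Homo sapiens), read by MTT assay, with a stated time of 72 h (a lower number here means a stronger inhibitor, a higher number a weaker inhibitor), compound 1 gives only a limit, > 20000 nM. In this assay compound 2 likewise gives only a limit, > 20000 nM. Compound 3 also gives only a limit, > 20000 nM. Compound 3 thus stands at the limit of > 20000 nM in this assay, at which 3 of the 3 values shown sit, and the step that the two limits leave unreadable from compound 2 to compound 3 (methyl in place of amino on an aromatic carbon) cannot be read.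

Compound 4 `Cc1nc(N)c2c(-c3ccco3)cn([C@@H]3O[C@H](CO)[C@@H](O)[C@H]3O)c2n1` differs from compound 3 by furan-2-yl in place of phenyl on an aromatic carbon. Among the measured compounds shown here, no measured step touches this place; the single measured step, a step that the two limits leave unreadable from compound 2 to compound 3, lies elsewhere and is itself unreadable. For the measured compounds named here, because the limit of > 20000 nM in this assay, at which 3 of the 3 values shown sit, holds every value so far, the likeliest outcome for compound 4 is a further limit. Compound 4 is expected to give about 30000 nM, within 10000 nM to 100000 nM. The step that the limit leaves unreadable from compound 3 to compound 4 is expected to show nothing beyond the scatter, as far as a limit allows.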

Compound 4, half-maximal inhibitory concentration: > 20000 nM
Compound 4 gave a limit, no number; the forecaster's own chance of this, stated with the estimate: 85%; the middle value lies beyond the limit too.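

Compound 4 gives only a limit in this assay, > 20000 nM, so the step from compound 3 to compound 4, furan-2-yl in place of phenyl, cannot be read. The compounds shown leave open what any single change on the shared core does to potency, with every value at one limit: the limit of > 20000 nM in this assay, at which 4 of the 4 values shown sit.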